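The source may report more compounds than this note shows. Statements on the series, on what has been measured and on what is new or still open speak of the compounds shown alone.

In a functional assay on B16 cells (Mus musculus), read by spectrophotometry, with a stated time of 3 days (on this read-out higher numbers stand for weaker inhibition and lower numbers for stronger inhibition), compounds sharing one core differ in the group on an amide-type nitrogen: compound 1 (`CNC(=S)N/N=C/c1cccc2ccccc12`) gives 2000 nM, compound 2 (`CCNC(=S)N/N=C/c1cccc2ccccc12`) gives 1100 nM and compound 3 (`COc1cccc(NC(=S)N/N=C/c2cccc3ccccc23)c1`) gives 830 nM. Compound 3 therefore sits level with compound 2 and apart from compound 1, though only modestly, as the steps show: a 1.3-fold lower number from compound 2 to compound 3 (0.12 log units; within the scatter) and a 2.4-fold lower number from compound 1 to compound 3 (0.38 log units; beyond the scatter). The remaining step is a 1.8-fold lower number from compound 1 to compound 2 (0.26 log units; within the scatter). Compound 4 (`S=C(N/N=C/c1cccc2ccccc12)NC1CCCCC1`) has cyclohexyl in place of 3-methoxyphenyl on an amide-type nitrogen. Going by the values given here, no measured compound carries cyclohexyl, so the closest guide is a 1.3-fold lower number from compound 2 to compound 3 (0.12 log units; within the scatter), and no change beyond the scatter is expected. For compound 4 the expected step is a 1.1-fold higher number from compound 3 to compound 4 (0.04 log units; within the scatter). The estimated value for compound 4 is 900 nM, with an expected range of 350 nM to 2300 nM.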

Compound 4, half-maximal inhibitory concentration: 290 nM
For compound 4 the middle estimate is 3.1-fold (0.49 log units) above the measured one; the whole stated range lies above it.
By their numbers in this assay, from the lowest: compound 4; then compounds 3, 2 and 1 (each within the scatter of the next, the first and the last beyond it).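

Cyclohexyl on the amide-type nitrogen in this assay stands clear of all three earlier groups (a 2.9-fold lower number from compound 3 to compound 4 (0.46 log units; beyond the scatter); a 3.8-fold lower number from compound 2 to compound 4 (0.58 log units; beyond the scatter); a 6.9-fold lower number from compound 1 to compound 4 (0.84 log units; beyond the scatter)), whereas among those groups only methyl and 3-methoxyphenyl stood apart. The non-aromatic carbon ring gives the lowest number despite having fewer heavy atoms than 3-methoxyphenyl, so heavy-atom count alone does not order this series. No measurement here explains the gain.

Open, from the compounds shown here alone, is whether plain phenyl would track compound 3 or compound 4, which would separate the ring type from the methoxy group. Also open, going by these compounds, are smaller or larger carbon rings, such as cyclopentyl or cycloheptyl.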